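The compounds below may be only part of what the source reports. "The series", "measured", "known", "first", "only" and "open" are said of these compounds alone.

Compound 2 `COc1ccc(F)cc1-c1cccc(-c2nn(CCCN)c(=O)o2)c1` stands at the top of the two numbers shown in a functional assay on the whole organism (strain Wistar albino) for inhibition, with Rattus norvegicus as the target, read by paw edema, with stated times of 30 min and 1 h, at a dose of 10 mg/kg by the oral route (a lower number here means less inhibition, a higher number more inhibition at the dose given (going by the name of the read-out)), yet only within the scatter: compound 2 gives 43%, while compound 1 `COc1ccc(F)cc1-c1cccc(-c2n[nH]c(=O)o2)c1` gives 41%, and the step of a number 2 percentage points higher from compound 1 to compound 2 (within the scatter). Compound 3 `COC(=O)CCCn1nc(-c2cccc(-c3cc(F)ccc3OC)c2)oc1=O` is not yet measured; it differs from compound 2 by methoxycarbonyl in place of amino on a saturated chain carbon, three bonds along the chain from an aromatic nitrogen. The one measured step altered the chain on the aromatic nitrogen itself and bears only loosely on this change; nothing shown points to a step beyond the scatter. Compound 3 is therefore expected at 43%, between 30% and 56%. The expected step is no change at the digits printed from compound 2 to compound 3 (within the scatter).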

Compound 3, a percentage reported as inhibition, in the whole organism at one dose (the size of the read-out at that dose, not a potency): 45%
Beside the measured number, compound 3's estimate is 2 percentage points below it; the range from low to high includes it.
By their numbers in this assay, from the lowest: compounds 1, 2 and 3 (each within the scatter of the next).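

In this assay the exchange of amino for methoxycarbonyl at the end of the chain gives a number 2 percentage points higher from compound 2 to compound 3 (within the scatter) and so leaves no readable change at this dose. Measured against the hydrogen on the aromatic nitrogen, 3-(methoxycarbonyl)propyl gives a number 4 percentage points higher from compound 1 to compound 3 (within the scatter) as well, so neither chain end shown separates from the parent. No measurement given here accounts for these results. Still open, on these data alone, is whether a carboxylic acid at the chain end, or a longer chain on the aromatic nitrogen, would move the number beyond the scatter.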